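Swapping the aryl group on the piperazine ring

The compounds below may be only part of what the source reports. "The series", "measured", "known", "first", "only" and "open" are said of these compounds alone.

Compound 1, `CCCc1nc(-c2ccccc2)c(CNCCN2CCN(c3ccccc3Cl)CC2)o1`, gives 60.1% in an assay on HEK293 cells for inhibition of Voltage-dependent T-type calcium channel subunit alpha-1G (Homo sapiens), read by fluorescence, tested at 10 uM; a lower number here means less inhibition, a higher number more inhibition at the concentration tested (going by the name of the read-out).
Compound 2, `CCCc1nc(-c2ccccc2)c(CNCCN2CCN(c3cccc(Cl)c3)CC2)o1`, gives 51.2% in this assay.
Compound 3, `CCCc1nc(-c2ccccc2)c(CNCCN2CCN(c3ccc(F)cc3)CC2)o1`, gives 54.1% in this assay.

The three measured compounds share one core and differ only in the aryl group attached to the ring nitrogen. Among the compounds with values here, their numbers sit close together: the step of a number 8.9 percentage points lower from compound 1 to compound 2 (within the scatter), the step of a number 6 percentage points lower from compound 1 to compound 3 (within the scatter) and the step of a number 2.9 percentage points higher from compound 2 to compound 3 (within the scatter) all fall within the scatter, so no compound can be called stronger or weaker than another. Compound 3 stands second highest of the three, with compound 2 nearest and compound 1 furthest, both within the scatter.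

Compound 4, `CCCc1nc(-c2ccccc2)c(CNCCN2CCN(c3ccccc3OC)CC2)o1`, is not yet measured. It differs from compound 3 in one place: 2-methoxyphenyl in place of 4-fluorophenyl on an amine nitrogen in a ring. Within the data shown here, no measured pair involves a methoxy group, so the only guidance comes from the aryl swaps already seen, which moved the read-out by a number 6 percentage points lower from compound 1 to compound 3 (within the scatter) and a number 2.9 percentage points higher from compound 2 to compound 3 (within the scatter), both within the scatter.

On that basis the step of a number 0.9 percentage points higher from compound 3 to compound 4 (within the scatter) is expected to stay within the scatter. Compound 4 is therefore estimated at 55% in this assay, with a range from 40% to 70%.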

Compound 4, a percentage reported as inhibition, at one concentration (the size of the read-out at that concentration, not a potency): 39.7%
Estimate against measurement, compound 4: 15.3 percentage points above; the measured number lies below the stated range.
By their numbers in this assay, from the lowest: compound 4; then compounds 2, 3 and 1 (each within the scatter of the next).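

Within the data shown here, on the amine nitrogen in a ring, the aryl swaps among the chloro and fluoro compounds all stayed within the scatter, so this position could have seemed indifferent to the aryl group, but 2-methoxyphenyl is the first group here to separate from the others, with a number 14.4 percentage points lower from compound 3 to compound 4 (beyond the scatter) and a number 11.5 percentage points lower from compound 2 to compound 4 (beyond the scatter) and a number 20.4 percentage points lower from compound 1 to compound 4 (beyond the scatter) in this assay as the steps that set compound 4 lowest of the four. The last of these steps is the cleanest comparison, since only methoxy in place of chloro on an aromatic carbon changes, which shows that the choice of group at that one carbon can alone move the read-out. The 2-methoxyphenyl group counts 1 hydrogen-bond acceptor where 4-fluorophenyl counts 0, yet no measurement available here bears on why the number falls.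

On these data alone, it remains open whether a 3-methoxyphenyl or 4-methoxyphenyl group would also give a lower number, or whether the drop belongs to the 2-methoxyphenyl group alone. As far as these compounds go, how a plain phenyl, a 2-hydroxyphenyl or a 2-ethoxyphenyl group would read on this nitrogen is also open.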